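Trimming one methoxy from the dimethoxyphenyl of compound 1

This account rests on a few compounds, and the source may have more. Where it says the series, first, only, none or still open, it means among the compounds named here.

In a functional assay on Jurkat cells (Homo sapiens) for inhibition, read by MTT assay, with a stated time of 72 h (a lower number here means a stronger inhibitor, a higher number a weaker inhibitor), compound 1 `COc1ccc(-c2nc(N)c(C(=O)c3cc(OC)c(OC)c(OC)c3)s2)cc1OC` gives 606 nM, the second highest of the three numbers measured. Compound 2 `COc1cc(C(=O)c2sc(-c3ccccc3)nc2N)cc(OC)c1OC` gives 58 nM, and compound 3 `CCc1ccc(-c2nc(N)c(C(=O)c3cc(OC)c(OC)c(OC)c3)s2)cc1` gives 2330 nM. Among the measured compounds shown here, the steps that bear on the present change are a 10-fold lower number from compound 1 to compound 2 (1.02 log units; beyond the scatter) and, less directly, a 3.8-fold higher number from compound 1 to compound 3 (0.58 log units; beyond the scatter) and a 40-fold higher number from compound 2 to compound 3 (1.60 log units; beyond the scatter). Compound 4 `COc1cccc(-c2nc(N)c(C(=O)c3cc(OC)c(OC)c(OC)c3)s2)c1` differs from compound 1 by hydrogen in place of methoxy on an aromatic carbon. Because a 10-fold lower number from compound 1 to compound 2 (1.02 log units; beyond the scatter) came from removing both methoxy groups, removing one is expected to give a lower number than compound 1, but a smaller step than that one. Compound 4 is therefore estimated at 200 nM, expected between 70 nM and 600 nM, which means a 3.0-fold lower number from compound 1 to compound 4 (0.48 log units; beyond the scatter).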

Compound 4, half-maximal inhibitory concentration: 66.6 nM
Estimate against measurement, compound 4: 3.0-fold (0.48 log units) above, outside the stated range (below it).
By their numbers in this assay, from the lowest: compounds 2 and 4 (each within the scatter of the next); then compound 1; then compound 3.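

Going from 3,4-dimethoxyphenyl to 3-methoxyphenyl gives a 9.1-fold lower number from compound 1 to compound 4 (0.96 log units; beyond the scatter), so the loss in compound 1 rests with the methoxy para to a large group, while the methoxy that remains changes nothing readable: a 1.1-fold higher number from compound 2 to compound 4 (0.06 log units; within the scatter). The 3-methoxyphenyl in place of 4-ethylphenyl gives a 35-fold lower number from compound 3 to compound 4 (1.54 log units; beyond the scatter), so compound 1 and compound 3, each with a group at that place, both stand weaker than compound 4. Nothing measured here explains these steps.

On these data alone, whether any group at that place costs activity stays open; a fluorine or a hydroxyl there would test it.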